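Notes on the step from compound 3 to compound 4

This account rests on a few compounds, and the source may have more. Where it says the series, first, only, none or still open, it means among the compounds named here.

The numbers from an ADME assay for permeability, using PAMPA, at pH 7.4 (a lower number here means that the compound crosses the layer more slowly, a higher number that the compound crosses the layer faster), stand close together: compound 1 `Cc1ccc(NC(=O)Nc2cc(C)nc3ccccc23)cc1` gives 669 10^-6 cm/s and compound 2 `COC(=O)c1ccc(NC(=O)Nc2cc(C)nc3ccccc23)cc1` gives 448 10^-6 cm/s while compound 3 `Cc1cc(NC(=O)Nc2ccc(OC(F)(F)F)cc2)c2ccccc2n1` gives 531 10^-6 cm/s and so lies within the scatter of both. Compound 4 `Cc1cc(NC(=O)Nc2ccc(SC(F)(F)F)cc2)c2ccccc2n1` is not yet measured; in it, (trifluoromethyl)sulfanyl takes the place of trifluoromethoxy (trifluoromethyl)sulfanyl in place of trifluoromethoxy on an aromatic carbon on an aromatic carbon. Within the data shown here, no measured step covers this exchange. The closest evidence is exchanges on an aromatic carbon: a 1.3-fold lower number from compound 1 to compound 3 (0.10 log units; within the scatter) and a 1.2-fold higher number from compound 2 to compound 3 (0.07 log units; within the scatter) and a 1.5-fold lower number from compound 1 to compound 2 (0.17 log units; within the scatter) all stay within the scatter. The expected step is a 1.1-fold higher number from compound 3 to compound 4 (0.02 log units; within the scatter) and so none beyond the scatter is expected in this assay here. For compound 4 the estimated value is 560 10^-6 cm/s (expected range 320 10^-6 cm/s to 900 10^-6 cm/s).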

Compound 4, apparent permeability: 206 10^-6 cm/s
For compound 4 the middle estimate is 2.7-fold (0.43 log units) above the measured one; measured number below the stated range.
By their numbers in this assay, from the lowest: compound 4; then compounds 2, 3 and 1 (each within the scatter of the next).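

In this assay, among these compounds, (trifluoromethyl)sulfanyl in place of trifluoromethoxy gives a 2.6-fold lower number from compound 3 to compound 4 (0.41 log units; beyond the scatter) and so the first step beyond the scatter at this place, although the two groups have the same count of heavy atoms, donors and acceptors. The new group also sets the compound apart from the other two, with a 2.2-fold lower number from compound 2 to compound 4 (0.34 log units; beyond the scatter) and a 3.2-fold lower number from compound 1 to compound 4 (0.51 log units; beyond the scatter) against only steps within the scatter among the earlier three. Nothing at hand accounts for this change.

From the compounds shown here alone, it remains open whether the lower number is confined to (trifluoromethyl)sulfanyl or also appears with other groups on this aromatic carbon, such as an amine, a carboxylic acid or a longer alkyl chain.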